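The compounds below may be only part of what the source reports. "The series", "measured", "known", "first", "only" and "open" are said of these compounds alone.

In a functional assay for binding affinity, with Rattus norvegicus as the target, read by GTPgammaS binding (a higher number here means that more compound is needed for the effect, a lower number that less compound is needed), compound 1, `O=C(O)c1cc(Cc2ccccc2)n[nH]1`, gives 70700 nM, while compound 2, `CCCc1cc(C(=O)O)n[nH]1`, gives 6100 nM. Compound 2 therefore has the lower of the two numbers, and its gap to compound 1 lies beyond the usual scatter. Less of compound 2 is needed for the effect.

Compound 3, `CCCCc1cc(C(=O)O)n[nH]1`, has not yet been measured. Its structure departs from that of compound 2 in one place: methyl in place of hydrogen on a saturated chain carbon, three bonds along the chain from an aromatic carbon. This is a methyl in place of hydrogen on a saturated chain carbon, three bonds along the chain from an aromatic carbon, and it turns propyl into butyl.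

Among the compounds with values here, no measured pair of compounds differs in only one place, so the data give no direct measure of such a change. The expectation therefore starts from compound 2 at 6100 nM and assumes no shift beyond the scatter in this assay, with only a slight lean towards a lower number. The expected change is a 1.4-fold lower number from compound 2 to compound 3 (0.13 log units; within the scatter). For compound 3, the estimated value is 4500 nM, with an expected range of 1800 nM to 11000 nM.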

Compound 3, half-maximal effective concentration: 4120 nM
The estimate for compound 3 lay 1.1-fold (0.04 log units) above the measured number; the measured number falls inside the stated range.
By their numbers in this assay, from the lowest: compounds 3 and 2 (each within the scatter of the next); then compound 1.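

Within the data shown here, the step in this assay, a 1.5-fold lower number from compound 2 to compound 3 (0.17 log units; within the scatter), is the first direct reading of a single change, since no earlier pair of compounds differed in only one place. It shows that methyl in place of hydrogen on a saturated chain carbon, three bonds along the chain from an aromatic carbon, which turns propyl into butyl, brings no shift beyond the scatter, so at this place in the chain the extension is tolerated in this assay. Nothing further is at hand that would account for this outcome.

The compounds shown leave open whether a longer chain such as pentyl or hexyl, or a branched group such as isopropyl, would also stay within the scatter of compound 3. They also leave open how a single change elsewhere on the shared core would read, for instance an ester or an amide in place of the carboxylic acid, and whether such a change would matter more than the length of the chain.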